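Methoxy for Chloro on the Longer-Chain Core

The source may report more compounds than this note shows. Statements on the series, on what has been measured and on what is new or still open speak of the compounds shown alone.

Measured compounds:
compound 1, `CCCCCCCCC(CCO)n1cnc2c(Cl)ncnc21`, 1650 nM
compound 2, `CCCCCCCCC(CCO)n1cnc2c(OC)ncnc21`, 12800 nM
compound 3, `CCCCCCCCCCC(CCO)n1cnc2c(Cl)ncnc21`, 4930 nM

In a functional assay on HCT-116 cells (Homo sapiens) for antiproliferative activity, read by MTT assay, with a stated time of 48 h (a lower number here means a stronger inhibitor, a higher number a weaker inhibitor), compound 1 gives 1650 nM, compound 2 gives 12800 nM and compound 3 gives 4930 nM. The change from compound 1 to compound 2 is methoxy in place of chloro on an aromatic carbon, and it made a step of a 7.8-fold higher number from compound 1 to compound 2 (0.89 log units; beyond the scatter). The cores of compound 1 and compound 3 differ by ethyl in place of hydrogen on a saturated chain carbon, nine bonds along the chain from an aromatic nitrogen, which gave a step of a 3.0-fold higher number from compound 1 to compound 3 (0.48 log units; beyond the scatter).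

Compound 4, `CCCCCCCCCCC(CCO)n1cnc2c(OC)ncnc21`, has not yet been measured in this assay. It differs from compound 3 by methoxy in place of chloro on an aromatic carbon, the same change as that from compound 1 to compound 2, made at the same place. Because compound 3 is weaker than compound 1 by a 3.0-fold higher number from compound 1 to compound 3 (0.48 log units; beyond the scatter), and because the earlier change gave a 7.8-fold higher number from compound 1 to compound 2 (0.89 log units; beyond the scatter), a step of similar size is expected from compound 3 to compound 4, namely a 7.7-fold higher number from compound 3 to compound 4 (0.89 log units; beyond the scatter). On that basis compound 4 is estimated at 38000 nM, with a likely range from 15000 nM to 100000 nM. For the measured compounds named here, with only one prior instance of the change, this expectation rests on a single pair.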

Compound 4, half-maximal inhibitory concentration: 7530 nM
Compound 4: the middle estimate sits 5.0-fold (0.70 log units) above what was measured, and the stated range ends above it.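

In this assay, methoxy in place of chloro on the longer-chain core gave a 1.5-fold higher number from compound 3 to compound 4 (0.18 log units; within the scatter), and set beside the earlier step, the change did not carry over at the same size: the same change on two cores in this assay, a 7.8-fold higher number (0.89 log units; beyond the scatter) from compound 1 to compound 2 and a 1.5-fold higher number (0.18 log units; within the scatter) from compound 3 to compound 4, 5.1-fold (0.71 log units) apart, beyond the scatter of two such steps Read the other way, ethyl in place of hydrogen on a saturated chain carbon, nine bonds along the chain from an aromatic nitrogen, gave a 1.7-fold lower number from compound 2 to compound 4 (0.23 log units; within the scatter), and this change also differed with its setting: the same change on two cores in this assay, a 3.0-fold higher number (0.48 log units; beyond the scatter) from compound 1 to compound 3 and a 1.7-fold lower number (0.23 log units; within the scatter) from compound 2 to compound 4, 5.1-fold (0.71 log units) apart, beyond the scatter of two such steps Across these four compounds, then, the two changes do not add up independently, as the size of each depends on the group present at the other place, but this single set of four shows neither the reason nor how either change would behave on a further core.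

The compounds shown leave open whether an amine or a thioether in place of chloro would show the same dependence on the chain. They also leave open how a longer chain, or a carboxylic acid in place of the terminal hydroxyl, would alter these steps.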